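The compounds below may be only part of what the source reports. "The series", "measured", "known", "first", "only" and "open" are said of these compounds alone.

Compound 1 `O=C1CCC2(c3ccc(F)cc3)OCCCN12` is the reference point of this small set. In a functional assay on the whole organism with Mus musculus as the target (on this read-out lower numbers stand for an effect already at smaller amounts and higher numbers for an effect only at larger amounts of compound), compound 1 gives 50 mg/kg, the lowest of the two numbers recorded. For the measured compounds named here, the nearest number belongs to compound 2 `COc1ccc(C23CCC(=O)N2CCCO3)cc1`, which in this assay gives 139 mg/kg; the step of a 2.8-fold higher number from compound 1 to compound 2 (0.44 log units; beyond the scatter) is the only measured change on the shared core. Compound 3 `O=C(CCC(=O)c1ccc(F)cc1)NCCCO` is the open-chain counterpart, and in this assay compound 3 reaches only a limit, > 400 mg/kg. That reading is the one described by the limit of > 400 mg/kg in this assay, at which 1 of the 3 values shown sits, and it supplies no number to compare.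

Compound 4 `O=C1CCC2(c3ccc(Cl)cc3)OCCCN12` differs from compound 1 by chloro in place of fluoro on an aromatic carbon. Going by the values given here, of the measured steps only the one from compound 1 to compound 2 touches the same aromatic carbon, and it moved the number modestly upward when methoxy replaced fluoro. Chloro is a different swap at that carbon, and no measured pair shows one halogen exchanged for another. For compound 4 a small step is therefore expected, a 1.2-fold higher number from compound 1 to compound 4 (0.08 log units; within the scatter), most likely within or only just beyond the scatter, with no firm direction. The estimate for compound 4 in this assay is 60 mg/kg, with a range from 25 mg/kg to 150 mg/kg.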

Compound 4, dose for half-maximal effect: 91.7 mg/kg
Compound 4: middle estimate off by 1.5-fold (0.18 log units), on the low side; the range from low to high includes it.
By their numbers in this assay, from the lowest: compounds 1, 4 and 2 (each within the scatter of the next, the first and the last beyond it). At a limit, above all of these: compound 3.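

At the aromatic carbon para to a large group, a second halogen can now be read against fluoro: a 1.8-fold higher number from compound 1 to compound 4 (0.26 log units; within the scatter), so in this assay chloro in place of fluoro does not separate from the reference. Chloro does not separate from methoxy either, a 1.5-fold lower number from compound 2 to compound 4 (0.18 log units; within the scatter), whereas the methoxy change alone remains beyond the scatter, a 2.8-fold higher number from compound 1 to compound 2 (0.44 log units; beyond the scatter); compound 4 therefore cannot be told apart from either of the other two compounds on the shared core, although those two differ from each other. The compounds shown give no measured property that would account for any of these steps.

Still open, going by these compounds, is how a nitrile, an amine or a carboxylic acid at this same aromatic carbon would read, and whether any group there could give a number clearly lower than that of compound 1 rather than one within the scatter of it or higher. Also open, on these data alone, is how a methyl group or a longer chain elsewhere on the shared core would read in this whole-organism setting, with the aromatic fluoro kept in place.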